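Swapping a methylphenoxy group for phenylsulfanyl: expected cytotoxicity

The compounds below may be only part of what the source reports. "The series", "measured", "known", "first", "only" and "open" are said of these compounds alone.

Measured compounds:
compound 1 `COc1ccnc(Nc2ccc(Cl)c(Oc3cccc(C)c3)c2)n1`: 18000 nM
compound 2 `COc1ccnc(Nc2ccc(Cl)c(Oc3ccc(C)cc3)c2)n1`: > 100000 nM

Two compounds share a common core and differ in the group attached through oxygen to the aromatic ring. In an ADME assay on MT2 cells (Homo sapiens) for cytotoxicity (a lower number here means that less compound is tolerated, a higher number that more compound is tolerated), compound 1 gives 18000 nM. For compound 2 this assay records > 100000 nM, which is a limit of the assay rather than a number, so compound 2 stands at the limit of > 100000 nM in this assay, at which 1 of the 2 values shown sits.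

Among the measured compounds shown here, the one measured step, an at least 5.5-fold higher number from compound 1 to compound 2 (0.74 log units; beyond the scatter), follows the move of the methyl group within the ring attached to the oxygen.

Compound 3 `COc1ccnc(Nc2ccc(Cl)c(Sc3ccccc3)c2)n1` has not yet been measured. The change from compound 2 to compound 3 is phenylsulfanyl in place of 4-methylphenoxy on an aromatic carbon. For the measured compounds named here, no measured step covers the loss of the methyl group or the exchange of oxygen for sulfur, so the step from compound 1 to compound 2 bears on it only loosely, and no direction can be taken from the data with confidence.

Compound 3 is therefore expected to sit between the two measured values, near 60000 nM, with a range from 15000 nM to 200000 nM; the expected step is an at least 1.6-fold lower number from compound 2 to compound 3 (0.22 log units; that floor lies within the scatter).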

Compound 3, half-maximal cytotoxic concentration: 21000 nM
For compound 3 the middle estimate is 2.9-fold (0.46 log units) above the measured one; the measured number falls inside the stated range.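

In this assay, phenylsulfanyl in place of 4-methylphenoxy gives an at least 4.7-fold lower number from compound 2 to compound 3 (0.67 log units; beyond the scatter), so the high tolerance recorded for compound 2 does not carry over to a phenyl ring linked through sulfur and lacking the methyl group. Set against 3-methylphenoxy, the same group gives a 1.2-fold higher number from compound 1 to compound 3 (0.07 log units; within the scatter), so compound 1 and compound 3 cannot be told apart here, and among these three groups only the 4-methylphenoxy group of compound 2 stands apart. The value for compound 2 is a limit and not a number, so the true size of its steps remains unknown: the limit of > 100000 nM in this assay, at which 1 of the 3 values shown sits.

The step to compound 3 exchanges oxygen for sulfur and removes the methyl group at once, and the compounds shown cannot separate these two changes; an unsubstituted phenoxy group and a 4-methylphenylsulfanyl group would each isolate one of them. Also open, from the compounds shown here alone, is how a ring joined through an amine, or a phenyl ring carrying a carboxylic acid, would behave in this assay.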